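Methoxy in place of ethylsulfanyl on the five-membered ring

This account rests on a few compounds, and the source may have more. Where it says the series, first, only, none or still open, it means among the compounds named here.

Measured so far:
Compound 1, `CCn1cc(-c2ccnc(Nc3ccc(OC)cc3OC)n2)c2ccccc21`: 3590 nM
Compound 2, `CCSc1nc(C)c(-c2ccnc(Nc3ccc(OC)cc3OC)n2)s1`: 32400 nM

Both compounds were tested in a functional assay on MV4-11 cells (Homo sapiens) for inhibition, read by resazurin assay, with a stated time of 72 h; a higher number here means a weaker inhibitor of growth, a lower number a stronger inhibitor of growth. Compound 2 has the highest number of the two, and its nearest neighbour is compound 1, whose number is lower by a margin that lies beyond the usual scatter. For the measured compounds named here, the two compounds share the pyrimidine-anilide part but differ in more than one place, so no single-step comparison between measured compounds is available; the two values show only that compound 1 is the stronger growth inhibitor of the pair in this assay.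

Compound 3, `COc1ccc(Nc2nccc(-c3sc(OC)nc3C)n2)c(OC)c1`, has not yet been measured. It differs from compound 2 in one place: methoxy in place of ethylsulfanyl on an aromatic carbon. Going by the values given here, nothing among the measured compounds tells how this exchange moves the number, so the expected step of a 1.3-fold lower number from compound 2 to compound 3 (0.11 log units; within the scatter) is treated as none beyond the scatter, with wide uncertainty in both directions. On that basis compound 3 is expected to give about 25000 nM in this assay, within a range from 7000 nM to 90000 nM.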

Compound 3, concentration for 50% growth inhibition: 1400 nM
Beside the measured number, compound 3's estimate is 18-fold (1.25 log units) above it; the whole stated range lies above it.
By their numbers in this assay, from the lowest: compound 3; then compound 1; then compound 2.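

In this assay the exchange of ethylsulfanyl for methoxy gives a 23-fold lower number from compound 2 to compound 3 (1.36 log units; beyond the scatter) at the aromatic carbon next to the ring nitrogen and next to the ring sulfur. For the compounds shown here, this is the first single-change comparison among the compounds, and it shows that growth inhibition is highly sensitive to the group on this carbon, since the step lies well beyond the scatter. Methoxy has fewer heavy atoms than ethylsulfanyl and carries oxygen where ethylsulfanyl carries sulfur, but no measurement in hand accounts for the size of this step.

The compounds shown leave open whether the shorter chain or the exchange of sulfur for oxygen matters more, a question that ethoxy and methylsulfanyl on the same carbon would separate. They also leave open how far this position tolerates other kinds of group, such as an amine or a carboxylic acid, since only ethylsulfanyl and methoxy are compared here.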